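A chloro swap at the limit of the assay

The compounds below may be only part of what the source reports. "The series", "measured", "known", "first", "only" and "open" are said of these compounds alone.

Compound 1 `O=c1oc2ccccc2c(N2CCN(c3ccc(F)cc3)CC2)c1CO`: > 50000 nM
Compound 2 `O=c1oc2ccccc2c(N2CCN(c3cccc(C(F)(F)F)c3)CC2)c1CO`: > 50000 nM

Both values above are limits of a functional assay on WM1361 cells (Homo sapiens) for inhibition, read by MTT assay, with a stated time of 24 h (on this read-out higher numbers stand for weaker inhibition and lower numbers for stronger inhibition), not numbers. Compound 2 stands at the limit of > 50000 nM in this assay, at which 2 of the 2 values shown sit. Compound 3 `O=c1oc2ccccc2c(N2CCN(c3cccc(Cl)c3)CC2)c1CO` differs from compound 2 by chloro in place of trifluoromethyl on an aromatic carbon, with chloro in place of trifluoromethyl on an aromatic carbon. Among the measured compounds shown here, no measured step shows what such a change does. With both measured compounds at the limit, no change beyond the scatter is expected in this assay, and the expected move is a step that the limit leaves unreadable from compound 2 to compound 3. Compound 3 is estimated at 60000 nM, with an expected range of 25000 nM to 150000 nM.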

Compound 3, half-maximal inhibitory concentration: > 50000 nM
Compound 3 ended at the assay's limit (the forecaster's own chance of this, stated with the estimate: 85%); the middle value does not contradict the limit.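

In this assay, compound 3 joins compound 1 and compound 2 at the assay's limit, and no step among these three compounds can be read: the limit of > 50000 nM in this assay, at which 3 of the 3 values shown sit.

Going by these compounds, how chloro and trifluoromethyl truly compare on the shared core remains open.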